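The compounds below may be only part of what the source reports. "The series", "measured", "known", "first", "only" and "open" are said of these compounds alone.

Measured compounds:
- compound 1, `Clc1ccccc1-n1cc(CSc2nc3ccccc3s2)nn1`, 78.1%
- compound 2, `Fc1ccc(-n2cc(CSc3nc4ccccc4s3)nn2)cc1`, 81.1%
- compound 3, `O=[N+]([O-])c1ccc(-n2cc(CSc3nc4ccccc4s3)nn2)cc1`, 65.5%

The three compounds share one core and differ only in the group on an aromatic nitrogen of the triazole-type ring. In a functional assay on the whole organism (strain Albino Wistar) for inhibition, with Rattus norvegicus as the target, read by paw edema, with stated times of 1 h and 5 h, at a dose of 10 mg/kg by the oral route (a higher number here means more inhibition at the dose given (going by the name of the read-out), a lower number less inhibition), compound 2 gives 81.1%, the highest of the three numbers; compound 1 is nearest, a number 3 percentage points higher from compound 1 to compound 2 (within the scatter), and compound 3 furthest, a number 15.6 percentage points lower from compound 2 to compound 3 (beyond the scatter).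

Compound 4, `Cc1ccccc1-n1cc(CSc2nc3ccccc3s2)nn1`, has not yet been measured. Its change from compound 2 is 2-methylphenyl in place of 4-fluorophenyl on an aromatic nitrogen. Going by the values given here, of the measured steps, the one from compound 1 to compound 2 bears on it most, since it too swaps the whole aryl group on the same aromatic nitrogen: a number 3 percentage points higher from compound 1 to compound 2 (within the scatter). The step from compound 2 to compound 3 changes a group on an aromatic carbon instead and is less comparable. The two aryl swaps that are known give numbers close to each other, so no step beyond the scatter is expected in this assay, and compound 4 is estimated at 77%, between 66% and 86%, meaning an expected change of a number 4.1 percentage points lower from compound 2 to compound 4 (within the scatter).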

Compound 4, a percentage reported as inhibition, in the whole organism at one dose (the size of the read-out at that dose, not a potency): 43.4%
Estimate against measurement, compound 4: 33.6 percentage points above, and the stated range ends above it.
By their numbers in this assay, from the lowest: compound 4; then compound 3; then compounds 1 and 2 (each within the scatter of the next).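

In this assay, going by these compounds alone, the aryl group on the aromatic nitrogen proves far less forgiving than the earlier compounds suggested: 2-methylphenyl in place of 4-fluorophenyl gives a number 37.7 percentage points lower from compound 2 to compound 4 (beyond the scatter), although both groups count the same number of heavy atoms and one aromatic ring of carbon only. Within the data shown here, the closest comparison is a number 34.7 percentage points lower from compound 1 to compound 4 (beyond the scatter), where methyl in place of chloro on an aromatic carbon is the only change, so a single small group on that aryl ring can separate a high number from a low one. Nothing available here accounts for this loss.

The compounds shown leave open whether a methoxy group or an amine in place of that methyl would follow compound 1 or compound 4. They also leave open whether the loss belongs to methyl alone or extends to a longer chain such as ethyl.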